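This account rests on a few compounds, and the source may have more. Where it says the series, first, only, none or still open, it means among the compounds named here.

Three compounds have been read in a physicochemical assay for lipophilicity, read by HPLC, measured as octanol-water partition; a lower number here means a more polar compound, a higher number a more lipophilic compound:

compound 1, `CC(C)=CCc1c(O)cc(/C=C/c2ccccc2)cc1O`, gives 3.46
compound 2, `Oc1ccc(/C=C/c2cccc(O)c2)cc1`, gives 2.08
compound 3, `CC(C)/C=C/c1c(O)cc(/C=C/c2ccc(O)c(O)c2)cc1O`, gives 2.44

Compound 1 stands highest of the three numbers. Compound 3 is the nearest to it, a number lower by a margin that lies beyond the scatter, and compound 2 is the furthest, lower still and also beyond the scatter. No pair among these three differs in only one place, so no single step between measured compounds can be drawn on.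

Compound 4, `CC(C)/C=C/c1c(O)cc(/C=C/c2ccccc2)cc1O`, has not yet been measured. It differs from compound 1 in one place: 3-methylbut-1-en-1-yl in place of 3-methylbut-2-en-1-yl on an aromatic carbon. The two share the same atoms, joined differently, with the same count of heavy atoms, donors and acceptors on the group that leaves and the group that enters.

Among the compounds with values here, with no comparable step among the measured compounds to draw on, the step from compound 1 to compound 4 in this assay is expected to be small, a number 0.04 log units higher from compound 1 to compound 4 (within the scatter), and not beyond the scatter in either direction. Compound 4 is therefore expected to give about 3.5, within a range from 3.1 to 3.9.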

Compound 4, partition coefficient: 3.71
Compound 4: middle estimate off by 0.21 log units, on the low side; the range from low to high includes it.
By their numbers in this assay, from the lowest: compound 2; then compound 3; then compounds 1 and 4 (each within the scatter of the next).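

In this assay, exchanging 3-methylbut-2-en-1-yl for 3-methylbut-1-en-1-yl on an aromatic carbon ortho to two hydroxy groups gives a number 0.25 log units higher from compound 1 to compound 4 (within the scatter) and so leaves the two compounds indistinguishable. Within the data shown here, this is the first single-place comparison, and it shows that, on this core and at this position, the two chains with the same atoms joined differently cannot be told apart in this assay. No measurement shown here offers an explanation for this result.

Going by these compounds, it remains open whether the same exchange would read alike on a core carrying a different set of hydroxy groups. Also unresolved is how far the number would move with a saturated 3-methylbutyl chain, a longer geranyl chain or a carboxylic acid at this position.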